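A few compounds are considered here, and "the series" means these few. Any claim that something is new, unique, unknown or untested is made for them only; others in the source may bear on it.

Measured compounds:
- Compound 1, `COc1ccc(Cl)cc1S(=O)(=O)Nc1cncc(-c2cccnc2)c1`: in an assay on isolated protein for inhibition of alkaline phosphatase, tissue-nonspecific isozyme (Homo sapiens) (a higher number here means a weaker inhibitor, a lower number a stronger inhibitor), compound 1 gives "not determined" (no result reported)
- Compound 2, `COc1ccc(F)cc1S(=O)(=O)Nc1cncc(C(N)=O)c1`: in this assay compound 2 gives 109 nM
- Compound 3, `COc1ccc(Cl)cc1S(=O)(=O)Nc1cncc(C(N)=O)c1`: in this assay compound 3 gives 105 nM

For the measured compounds named here, compound 3 therefore stands alongside the only other measured compound rather than apart from it: the step from compound 2 to compound 3 is a 1.0-fold lower number from compound 2 to compound 3 (0.02 log units; within the scatter), so the two numbers cannot be told apart. Compound 1 carries a different group on the shared core and contributes no number at all.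

The next compound is compound 4, `COc1ccc(OC(F)(F)F)cc1S(=O)(=O)Nc1cncc(C(N)=O)c1`. It differs from compound 3 in one place: trifluoromethoxy in place of chloro on an aromatic carbon.

Going by the values given here, only one measured step bears on this change, and only loosely. From compound 2 to compound 3 one halogen replaced another at the same aromatic carbon, and the number barely moved (a 1.0-fold lower number from compound 2 to compound 3 (0.02 log units; within the scatter)). Among the compounds with values here, no measured pair shows a trifluoromethoxy group entering anywhere, so the change to compound 4 is genuinely untested. Within the data shown here, the single available comparison suggests that swapping groups at this position leaves the number where it is, so the expected step from compound 3 to compound 4 in this assay is a 1.2-fold higher number from compound 3 to compound 4 (0.09 log units; within the scatter), not clearly beyond the scatter in either direction. Compound 4 is accordingly estimated to give 130 nM in this assay, with a plausible range from 50 nM to 350 nM.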

Compound 4, half-maximal inhibitory concentration: 1560 nM
Beside the measured number, compound 4's estimate is 12-fold (1.08 log units) below it, and the stated range ends below it.
By their numbers in this assay, from the lowest: compounds 3 and 2 (each within the scatter of the next); then compound 4.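

In this assay, the aromatic carbon para to a methoxy group turns out not to treat every group alike: fluoro and chloro could not be told apart there, yet trifluoromethoxy in place of chloro brings a 15-fold higher number from compound 3 to compound 4 (1.17 log units; beyond the scatter), and trifluoromethoxy in place of fluoro brings a 14-fold higher number from compound 2 to compound 4 (1.16 log units; beyond the scatter). For the compounds shown here, the flat step between the two halogens therefore described only that one pair of groups, not the position as a whole, which can clearly shift the number towards a weaker inhibitor when 5 heavy atoms enter where 1 left. Nothing measured here accounts for this jump.

The compounds shown leave open which part of the trifluoromethoxy group goes with the higher number, a question that a plain methoxy group or a trifluoromethyl group on the same carbon could help to separate. They also leave open whether any group at this position gives a lower number than chloro and fluoro do, for example an amine or a short carbon chain such as methyl.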